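Benzyl substituent swap on the acylsulfonamide side chain

This account rests on a few compounds, and the source may have more. Where it says the series, first, only, none or still open, it means among the compounds named here.

Compound 1 `N#Cc1cc2c(nc1N1CCC(C(=O)NS(=O)(=O)Cc3ccccc3F)CC1)COC2=O` carries a 2-fluorobenzyl group on the acylsulfonamide and, in a functional assay (Platelet, plasma) for inhibition, with Homo sapiens as the target (a higher number here means a weaker inhibitor, a lower number a stronger inhibitor), compound 1 gives 23700 nM. Of the two numbers recorded in this assay, compound 1 stands highest, its nearest neighbour being compound 2 `CC1(C(=O)NS(=O)(=O)Cc2ccc(Cl)cc2)CCN(c2nc3c(cc2C#N)C(=O)OC3)CC1`, which in this assay gives 3010 nM; compound 2 differs from compound 1 in more than one place, so the two values only bracket the set. Compound 3 `N#Cc1cc2c(nc1N1CCC(C(=O)NS(=O)(=O)Cc3ccccc3)C1)COC2=O` is recorded in this assay only as a limit, > 300000 nM. That limit is described as the limit of > 300000 nM in this assay, at which 1 of the 3 values shown sits.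

Compound 4 `N#Cc1ccc(CS(=O)(=O)NC(=O)C2CCN(c3nc4c(cc3C#N)C(=O)OC4)CC2)cc1` is not yet measured. Its relation to compound 1 is 4-cyanophenyl in place of 2-fluorophenyl on a saturated chain carbon bound to a sulfonyl sulfur. Within the data shown here, no measured pair differs in a single place, so no single measured step in this assay is available to anchor the change. The lower value of compound 2, which also bears a group on the benzyl ring, at 3010 nM, suggests that a ring substituent of this kind need not raise the number.

For compound 4 the expected value in this assay is 12000 nM, with a range from 3000 nM to 50000 nM. The step from compound 1 to compound 4 is therefore estimated as a 2.0-fold lower number from compound 1 to compound 4 (0.30 log units; within the scatter), a modest lowering that may not exceed the scatter.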

Compound 4, half-maximal inhibitory concentration: 8900 nM
For compound 4 the middle estimate is 1.3-fold (0.13 log units) above the measured one, and the stated range covers the measured number.
By their numbers in this assay, from the lowest: compound 2; then compound 4; then compound 1. At a limit, above all of these: compound 3.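

In this assay, the change from 2-fluorobenzyl to 4-cyanobenzyl gives a 2.7-fold lower number from compound 1 to compound 4 (0.43 log units; beyond the scatter), the first single-place step available in this series. It shows that the number responds to the aryl group on a saturated chain carbon bound to a sulfonyl sulfur, and that this position accepts 4-cyanophenyl in place of 2-fluorophenyl with a modest lowering rather than a loss. The step removes one substituent and introduces another at a different ring position. It reads only as the effect of the whole swap, and no measured property among the data accounts for its size.

Still open, as far as these compounds go, is how much of the step belongs to losing the fluorine and how much to gaining the nitrile, a question that an unsubstituted benzyl group on the core of compound 1 would help to separate. Also open, from the compounds shown here alone, is how the number would respond to a carboxylic acid or an aminomethyl group on the benzyl ring, or to a longer chain, such as phenethyl, between the sulfonyl sulfur and the ring.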